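Side-chain step from compound 3 to compound 4

A few compounds are considered here, and "the series" means these few. Any claim that something is new, unique, unknown or untested is made for them only; others in the source may bear on it.

Measured in a functional assay on HL-60 cells (Homo sapiens) for cytotoxicity, read by WST assay, with a stated time of 48 h (a higher number here means a weaker inhibitor, a lower number a stronger inhibitor), so far
- compound 1 `COC[C@H](C(C)C)C(c1ccc(O)c(OC)c1)c1ccc(O)c(OC)c1` gives 72000 nM
- compound 2 `COc1cc(C(c2ccc(O)c(OC)c2)[C@@H](C)[C@@H](C)CF)ccc1O` gives 38000 nM
- compound 3 `COc1cc(C(c2ccc(O)c(OC)c2)[C@@H](C)[C@H](C)CO)ccc1O` gives > 100000 nM

Compound 3 stands at > 100000 nM as a limit of the assay and not a number.

Compound 4 `CC[C@H](C(C)C)C(c1ccc(O)c(OC)c1)c1ccc(O)c(OC)c1` has 1-isopropylpropyl in place of 2-(hydroxymethyl)-1-methylpropyl on a saturated chain carbon bound to two aromatic carbons and awaits measurement.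

For the measured compounds named here, three measured steps bear on this change. Going by the values given here, the series shows an at least 2.6-fold higher number from compound 2 to compound 3 (0.42 log units; beyond the scatter) as the only step beyond the scatter. It also shows an at least 1.3-fold higher number from compound 1 to compound 3 (0.14 log units; that floor lies within the scatter) with a floor inside the scatter, and a 1.9-fold lower number from compound 1 to compound 2 (0.28 log units; within the scatter) within the scatter. Among these three compounds, only compound 3 carries the hydroxymethyl chain and only compound 3 reaches the limit. Without that chain, compound 1 gives 72000 nM and compound 2 gives 38000 nM as numbers within the scatter of each other. Compound 4 also lacks that chain, so it is expected to fall in the same region of this assay as those two.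

A lower number is therefore expected, with an estimated at least 2.2-fold lower number from compound 3 to compound 4 (0.34 log units; beyond the scatter) as the step.

For compound 4 the estimated value is 45000 nM with an expected range from 15000 nM to 100000 nM in this assay as the read-out.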

Compound 4, half-maximal inhibitory concentration: 16000 nM
Compound 4: the middle estimate sits 2.8-fold (0.45 log units) above what was measured; low and high end bracket the measured number.
By their numbers in this assay, from the lowest: compound 4; then compounds 2 and 1 (each within the scatter of the next). At a limit, above all of these: compound 3.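

In this assay, the all-carbon 1-isopropylpropyl chain of compound 4 separates from both other chains that lack hydroxymethyl, although compound 1 and compound 2 lie within the scatter of each other: the steps are a 2.4-fold lower number from compound 2 to compound 4 (0.38 log units; beyond the scatter) and a 4.5-fold lower number from compound 1 to compound 4 (0.65 log units; beyond the scatter), the latter being methyl in place of methoxy on a saturated chain carbon, three bonds along the chain from two aromatic carbons. The change from the hydroxymethyl chain gives an at least 6.2-fold lower number from compound 3 to compound 4 (0.79 log units; beyond the scatter), and with all its steps beyond the scatter, compound 4 is the strongest of the four compounds in this assay. Compound 3 remains at a limit of the assay and not a number, so the true size of that step stays unknown: the limit of > 100000 nM in this assay, at which 1 of the 4 values shown sits.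

The compounds shown leave open whether a longer all-carbon chain or an amine on this chain would lower the number further. They also cannot separate the loss of the hydroxyl from the change in chain branching, as compound 3 and compound 4 differ in both.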